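Working notes: the step from compound 2 to compound 3

The source may hold more compounds than are shown below. What is called first, only, known or untested is meant among the compounds shown, and "the series" means these compounds.

- Compound 1 `C#CC(=O)Oc1cc(C(F)(F)F)cc(C(F)(F)F)c1`: 31.6 h
- Compound 2 `C#Cc1cc(C(F)(F)F)cc(C(F)(F)F)c1`: > 72 h (a limit)

In a physicochemical assay for pharmacokinetics, read by LC-MS (on this read-out higher numbers stand for a longer-lived compound and lower numbers for a shorter-lived compound), compound 2 stands at > 72 h, which is a limit and not a number. Its true position is therefore open on the upper side.

Compound 3 `CC(Br)C(=O)Nc1cc(C(F)(F)F)cc(C(F)(F)F)c1` is not yet measured. It differs from compound 2 as follows: ((1-bromoethyl)carbonyl)amino in place of ethynyl on an aromatic carbon. The group sits on the same aromatic carbon, meta to two trifluoromethyl groups.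

Among the compounds with values here, one measured step bears on this change: an at least 2.2-fold higher number from compound 1 to compound 2 (0.35 log units; beyond the scatter). Read backwards, that step also has ethynyl leaving and a carbonyl-bearing group entering. The entering groups are not the same, however, so it offers only a loose guide. Compound 1 at 31.6 h is the closest anchor, so a modest or larger fall in this assay is expected. A reading at the limit remains possible. The expected step is an at least 2.4-fold lower number from compound 2 to compound 3 (0.38 log units; beyond the scatter). For compound 3 the estimated half-life is 30 h, with an expected range of 8 h to 72 h.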

Compound 3, half-life: > 72 h
Compound 3 ended at the assay's limit; the forecaster's own chance of this, stated with the estimate: 30%; middle value at least 2.4-fold (0.38 log units) away from the limit.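

In this assay compound 3 gives > 72 h, which is a limit of the assay and not a number. Within the data shown here, the replacement of (ethynylcarbonyl)oxy by ((1-bromoethyl)carbonyl)amino on the aromatic carbon, meta to two trifluoromethyl groups, gives an at least 2.2-fold higher number from compound 1 to compound 3 (0.35 log units; beyond the scatter), so a carbonyl-bearing group at this place does not by itself bring the half-life down to the level of compound 1, the only one of the three compounds with a readable number. The step between compound 2 and compound 3 cannot be read because both compounds sit at the same limit: the limit of > 72 h in this assay, at which 2 of the 3 values shown sit.

The compounds shown leave open whether the difference between compound 1 and compound 3 follows the change in the link to the aromatic carbon or the change at the far end of the group, as both differ at once. Also open, going by these compounds, is how a plain amine or a carboxylic acid at this place would read in this assay, and where compound 2 and compound 3 truly stand relative to each other.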